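Methoxy-to-hydroxy step on a pyrazole urea series

A few compounds are considered here, and "the series" means these few. Any claim that something is new, unique, unknown or untested is made for them only; others in the source may bear on it.

Measured so far:
compound 1, `O=C(Nc1cccc(-n2cc(-c3ccncc3)c(-c3ccc(Cl)c(O)c3)n2)c1)Nc1cccc(C(F)(F)F)c1`: > 32500 nM
compound 2, `COc1cc(-c2nn(-c3cccc(NC(=O)Nc4cc(C(F)(F)F)cc(C(F)(F)F)c4)c3)cc2-c2ccncc2)ccc1Cl`: 2130 nM

In a functional assay on A549 cells (Homo sapiens) for inhibition, read by sulforhodamine B assay, with a stated time of 48 h (on this read-out lower numbers stand for stronger inhibition of growth and higher numbers for weaker inhibition of growth), compound 2 gives 2130 nM. Among the measured compounds shown here, this is the only number in the set. For compound 1 the read-out is a limit of the assay, > 32500 nM, not a number, so compound 2 stands alone as the single quantified point; the limit of > 32500 nM in this assay, at which 1 of the 2 values shown sits, marks where the other entry sits. For the measured compounds named here, compound 1 and compound 2 differ in more than one place, so no single-change step between them can be read.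

Compound 3, `O=C(Nc1cccc(-n2cc(-c3ccncc3)c(-c3ccc(Cl)c(O)c3)n2)c1)Nc1cc(C(F)(F)F)cc(C(F)(F)F)c1`, is not yet measured. It keeps the bis(trifluoromethyl) urea end of compound 2 and carries the change (hydrogen in place of methyl on an oxygen on an aromatic ring), in words: hydrogen in place of methyl on an oxygen on an aromatic ring, read one bond further out as 4-chloro-3-methoxyphenyl to 4-chloro-3-hydroxyphenyl. Going by the values given here, no measured step covers this change. Among the compounds with values here, the only hydroxy compound in hand, compound 1, sits at a limit, which gives no size. The expected step from compound 2 to compound 3 is a 3.3-fold higher number from compound 2 to compound 3 (0.52 log units; beyond the scatter), toward weaker inhibition of growth, beyond the scatter but not certain. Compound 3 is estimated at 7000 nM, within 2500 nM to 32500 nM.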

Compound 3, concentration for total growth inhibition: 1690 nM
For compound 3 the middle estimate is 4.1-fold (0.62 log units) above the measured one; measured number below the stated range.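

In this assay the change from methoxy to hydroxy gives a 1.3-fold lower number from compound 2 to compound 3 (0.10 log units; within the scatter), so with the bis(trifluoromethyl) urea end in place, 4-chloro-3-methoxyphenyl and 4-chloro-3-hydroxyphenyl read alike in this series. The urea end separates the two hydroxy compounds, with an at least 19-fold lower number from compound 1 to compound 3 (1.28 log units; beyond the scatter), so a hydroxy group on this aromatic ring does not by itself go with the weak read-out of compound 1. Compound 1 gives > 32500 nM as a limit of the assay and not a number, so the size of that step has only a lower bound: the limit of > 32500 nM in this assay, at which 1 of the 3 values shown sits.

The compounds shown leave open whether methoxy and hydroxy also read alike when the urea end carries a single trifluoromethyl, since the one-trifluoromethyl series is represented here by compound 1 alone. Also open is how far this place accepts other groups on the aromatic ring, such as an amine, a carboxylic acid or a longer alkoxy chain like ethoxy, since hydroxy and methoxy are the only two groups shown there.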